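Chloro for methyl on the benzyl ring of compound 2

A few compounds are considered here, and "the series" means these few. Any claim that something is new, unique, unknown or untested is made for them only; others in the source may bear on it.

Of the compounds shown here, two have been measured in an assay on CHO cells for displacement of a labelled ligand from adenosine receptor A3 (Homo sapiens), read by scintillation counting, tested at 1 uM; on this read-out higher numbers stand for more inhibition at the one concentration tested (going by the name of the read-out) and lower numbers for less inhibition. Compound 1 `CC(C)Cc1nc(N)c2nn(-c3ccccc3)cc2n1` carries an isopropyl group on the chain attached to the shared core, and in this assay compound 1 gives 13%. Compound 2 `Cc1ccc(Cc2nc(N)c3nn(-c4ccccc4)cc3n2)cc1` carries a 4-methylphenyl group in its place, and in this assay compound 2 gives 39%, the higher of the two numbers seen so far; the step is a number 26 percentage points higher from compound 1 to compound 2 (beyond the scatter). Compound 3 `Nc1nc(Cc2ccc(Cl)cc2)nc2cn(-c3ccccc3)nc12` keeps the benzyl arrangement of compound 2 and alters only the group on that ring: chloro in place of methyl on an aromatic carbon. Among the compounds with values here, no measured step bears on this kind of exchange; the only step known swaps the whole isopropyl for 4-methylphenyl, a far larger change than the one proposed here. The exchange is therefore expected to make no difference beyond the usual scatter, a number 1 percentage points higher from compound 2 to compound 3 (within the scatter). Compound 3 is estimated at 40%, with a range from 20% to 60%.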

Compound 3, a percentage reported as inhibition, at one concentration (the size of the read-out at that concentration, not a potency): 11%
Compound 3: middle estimate off by 29 percentage points, on the high side; measured number outside the range, below it.
By their numbers in this assay, from the lowest: compounds 3 and 1 (each within the scatter of the next); then compound 2.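

In this assay the group on this ring carbon turns out to matter: with one heavy atom leaving and one entering, chloro for methyl gives a number 28 percentage points lower from compound 2 to compound 3 (beyond the scatter) and so removes the gain seen with the 4-methylbenzyl group. The gain therefore does not come from any benzyl group as such, since the other step reads a number 2 percentage points lower from compound 1 to compound 3 (within the scatter) and leaves the 4-chlorophenyl group level with the isopropyl group on the same chain carbon. No measurement on hand gives a reason for this drop.

On these data alone, it remains open whether compound 2 is helped by methyl in particular or whether ethyl, methoxy or an amine in the same place would give a number like that of compound 2. Also open, as far as these compounds go, is whether fluoro or bromo would behave as chloro does.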